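The compounds below may be only part of what the source reports. "The series", "measured", "known", "first", "only" and "open" are said of these compounds alone.

The three measured compounds and their readings in a functional assay on HEK-293T cells (Homo sapiens) for cytotoxicity, read by MTT assay; on this read-out higher numbers stand for lower toxicity in this test and lower numbers for higher toxicity in this test:

compound 1, `COc1cc(Nc2c(-c3ccc(Cl)cc3)nc3cnccn23)cc(OC)c1OC`: 25000 nM
compound 2, `COc1cc(Nc2c(-c3ccc(F)cc3)nc3cnccn23)cc(OC)c1OC`: 36000 nM
compound 3, `COc1ccc(Nc2c(-c3ccc(F)cc3)nc3cnccn23)cc1`: 56000 nM

Compound 1 and compound 2 share one core and differ in a single place, namely (chloro in place of fluoro on an aromatic carbon). That change made a 1.4-fold lower number from compound 2 to compound 1 (0.16 log units; within the scatter). Compound 3 shares its core with compound 2 as well, but the difference between the two cores is not broken down here. What the values show is that compound 3 and compound 2 lie within the scatter of each other, while the gap between compound 3 and compound 1 lies beyond it.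

Compound 4, `COc1ccc(Nc2c(-c3ccc(Cl)cc3)nc3cnccn23)cc1`, is not yet measured in this assay. It stands to compound 3 exactly as compound 1 stands to compound 2: the change is chloro in place of fluoro on an aromatic carbon. The surroundings of the place read the same word for word in both cases, so this is the same change, made for the second time among these compounds.

The expectation for compound 4 rests on two things: compound 3 gives 56000 nM, and the earlier step was a 1.4-fold lower number from compound 2 to compound 1 (0.16 log units; within the scatter). This estimate means an expected step of a 1.4-fold lower number from compound 3 to compound 4 (0.15 log units; within the scatter), a step of about the size seen before and again within the scatter. Compound 4 is therefore expected to give 40000 nM. For compound 4 the expected range runs from 20000 nM to 80000 nM.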

Compound 4, concentration lethal to 50% of the cells: 34000 nM
Compound 4: middle estimate off by 1.2-fold (0.07 log units), on the high side, within the range that was stated.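

In this assay, putting chloro in place of fluoro, read here as 4-fluorophenyl to 4-chlorophenyl on an aromatic carbon, gave a 1.6-fold lower number from compound 3 to compound 4 (0.22 log units; within the scatter). Set beside the same change on the other core, the two steps agree: the same change on two cores in this assay, a 1.4-fold lower number (0.16 log units; within the scatter) from compound 2 to compound 1 and a 1.6-fold lower number (0.22 log units; within the scatter) from compound 3 to compound 4, 1.1-fold (0.06 log units) apart, within the scatter of two such steps This shows that, across these two cores, the change carried over without any step that can be told apart from repeat measurement, so the reading on one core was a fair guide to the reading on the other; it does not show that chloro has a real effect of its own in this test, since each step on its own lies within the scatter, and two cores are too few to support a rule for the wider series.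

The compounds shown carry only fluoro and chloro at this place, so it remains open whether the same agreement between cores would hold for a larger or quite different group there, such as bromo, a nitrile, an amine or a carboxylic acid. Going by these compounds, it also remains open whether a change of this kind would give a step beyond the scatter on either core.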